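Replacing a triazolyl group with 1,1-difluoroethyl on compound 3

The source may report more compounds than this note shows. Statements on the series, on what has been measured and on what is new or still open speak of the compounds shown alone.

Compound 1 `COc1ccc(F)cc1N1C(=O)CSC1c1cccc(C(=O)NCCCCn2cccn2)c1` gives 1310 mL.min-1.g-1
Compound 2 `COc1ccccc1N1C(=O)CSC1c1cc(F)cc(C(=O)NCCCCc2ccccc2)c1` gives 1430 mL.min-1.g-1
Compound 3 `O=C(NCCCCc1ccccc1)c1cccc(C2SCC(=O)N2c2cccc(-c3c[nH]nn3)c2)c1` gives 951 mL.min-1.g-1

All three were measured in an ADME assay on microsomes from liver (Mus musculus) for metabolic stability, read by LC-MS, using NADPH, with a stated time of 10 min, tested at 0.1 uM (on this read-out higher numbers stand for fast clearance and lower numbers for slow clearance), and their values lie within the usual scatter of one another. Compound 3, at 951 mL.min-1.g-1 here, therefore stands level with compound 1 and compound 2.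

Compound 4 `CC(F)(F)c1cccc(N2C(=O)CSC2c2cccc(C(=O)NCCCCc3ccccc3)c2)c1` is compound 3 with 1,1-difluoroethyl in place of 1H-1,2,3-triazol-4-yl on an aromatic carbon of a six-membered aromatic ring of carbon only, meta to a large group. Going by the values given here, no two measured compounds differ in one place alone, so nothing here shows directly what such a swap does in this assay on its own. Compound 2, which has no 1H-1,2,3-triazol-4-yl, gives 1430 mL.min-1.g-1 and stays within the scatter of compound 3, so no change beyond the scatter is expected. An estimated 1.3-fold higher number from compound 3 to compound 4 (0.12 log units; within the scatter) is expected to remain within that scatter. For compound 4 the estimated value is 1250 mL.min-1.g-1 with an expected range from 750 mL.min-1.g-1 to 2100 mL.min-1.g-1 in this measurement.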

Compound 4, intrinsic clearance in microsomes: 2010 mL.min-1.g-1
Compound 4: middle estimate off by 1.6-fold (0.21 log units), on the low side, within the range that was stated.
By their numbers in this assay, from the lowest: compounds 3, 1, 2 and 4 (each within the scatter of the next, the first and the last beyond it).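

In this assay, going by these compounds alone, the change from 1H-1,2,3-triazol-4-yl to 1,1-difluoroethyl gives a 2.1-fold higher number from compound 3 to compound 4 (0.33 log units; beyond the scatter) and provides the first comparison here in which two compounds differ in one place alone. It shows that this position, on an aromatic carbon meta to a large group, is not indifferent to the group it carries: the pair differs beyond the usual scatter, with the triazolyl compound cleared more slowly. Nothing measured here explains the difference.

Whether the ring, the hydrogen-bond donor or something else in the triazolyl group accounts for the gap remains open. Also open is where a carboxylic acid or an amine at this position would fall, and whether the same swap would give a similar step on the other compounds shown.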